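Swapping carboxy for hydrogen on compound 2

The source may hold more compounds than are shown below. What is called first, only, known or untested is meant among the compounds shown, and "the series" means these compounds.

Compound 1 `O=C(Nc1ccn(C[C@@H]2O[C@H](CO)[C@@H](O)[C@H](F)C2=O)c(=O)n1)c1ccccc1`: 2500 ug/mL
Compound 2 `O=C(O)OC[C@@H]1C=C(F)C(=O)[C@H](Cn2ccc(NC(=O)c3ccccc3)nc2=O)O1`: 1000 ug/mL

Both numbers were read in a functional assay on Caco-2 cells (Homo sapiens) for inhibition, with a stated time of 72 h (a higher number here means a weaker inhibitor, a lower number a stronger inhibitor), and are all that is known so far. Compound 2 at 1000 ug/mL holds the lower of the two numbers, and compound 1 at 2500 ug/mL sits higher by a gap beyond the scatter. Compound 3 `O=C(Nc1ccn(C[C@@H]2O[C@H](CO)C=C(F)C2=O)c(=O)n1)c1ccccc1` awaits measurement. It differs from compound 2 by hydrogen in place of carboxy on an oxygen on a saturated carbon with hydrogen in place of carboxy on an oxygen on a saturated carbon. Going by the values given here, compound 1 and compound 2 differ in more than one place, so no measured step speaks to this change. In this assay the expected change is no change at the digits printed from compound 2 to compound 3 (within the scatter) and thus none beyond the scatter. Compound 3 is estimated at 1000 ug/mL (range 400 ug/mL to 2500 ug/mL).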

Compound 3, half-maximal inhibitory concentration: 200 ug/mL
Estimate against measurement, compound 3: 5.0-fold (0.70 log units) above; the measured number lies below the stated range.
By their numbers in this assay, from the lowest: compound 3; then compound 2; then compound 1.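

In this assay, going by these compounds alone, hydrogen in place of carboxy on an oxygen on a saturated carbon gives a 5.0-fold lower number from compound 2 to compound 3 (0.70 log units; beyond the scatter) as the first single-place step in this set, so this position is not silent to the change from carboxyoxy to hydroxy. Nothing shown accounts for the size or direction of this step. The compounds shown leave open what another group on this oxygen, such as methyl or acetyl, would do to the number. They also leave open whether an amine in place of the hydroxy would keep it as low.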